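The source may report more compounds than this note shows. Statements on the series, on what has been measured and on what is new or still open speak of the compounds shown alone.

Measured so far:
compound 1 `N#CNC(=N)NCCCCn1nc(-c2ccccc2)ccc1=O` — 59.3 mg/kg
compound 2 `CN(C)/C(=N/CCCCCCn1nc(-c2ccccc2)ccc1=O)NC#N` — 92.5 mg/kg

Both numbers come from a functional assay on the whole organism with Rattus norvegicus as the target; a higher number here means that more compound is needed for the effect, a lower number that less compound is needed. Compound 1 gives 59.3 mg/kg and carries the lowest of the two numbers, but compound 2 with 92.5 mg/kg lies within the usual scatter of it, so the two read as equivalent and no order between them is claimed. For the measured compounds named here, no pair of measured compounds differs in a single place, so no step size has yet been established.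

Compound 3 `CC/N=C(\S)NCCCCn1nc(-c2ccccc2)ccc1=O` has not been measured. It differs from compound 1 as follows: a group of 5 heavy atoms (3 carbon, 1 nitrogen, 1 sulfur; no ring) in place of a group of 5 heavy atoms (2 carbon, 3 nitrogen; no ring), on an amine nitrogen. Going by the values given here, nothing in the two measured compounds shows how this assay responds to a change of this kind; the only comparison available, compound 1 against compound 2, involves two changes at once and stays within the scatter. The expectation is therefore that a 1.0-fold higher number from compound 1 to compound 3 (0.01 log units; within the scatter) amounts to no step beyond the scatter, in either direction, and that the new group carries the number neither clearly up nor clearly down. For compound 3 the estimated value in this assay is 60 mg/kg, with a range from 25 mg/kg to 150 mg/kg.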

Compound 3, dose for half-maximal effect: 19.8 mg/kg
Compound 3: the middle estimate sits 3.0-fold (0.48 log units) above what was measured; the whole stated range lies above it.
By their numbers in this assay, from the lowest: compound 3; then compounds 1 and 2 (each within the scatter of the next).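

In this assay the amine nitrogen whose other neighbour is a saturated chain carbon proves responsive: a group of 5 heavy atoms (3 carbon, 1 nitrogen, 1 sulfur; no ring) in place of a group of 5 heavy atoms (2 carbon, 3 nitrogen; no ring) gives a 3.0-fold lower number from compound 1 to compound 3 (0.48 log units; beyond the scatter). For the compounds shown here, this is the first single-place step and the first to lie beyond the scatter, so a change at this position can move the dose needed while the rest of compound 1 stays the same. The exchange also removes the triple bond and leaves 1 hydrogen-bond donor and 1 hydrogen-bond acceptor in place of 2 of each, and nothing measured connects any of these differences to the size of the step.

Going by these compounds, with a single replacement at this position, it remains open whether the step depends on the sulfur, since a matching group with oxygen in its place, such as a urea, would separate that atom from the rest of the change. On these data alone, it also remains open whether the same group gives a similar step on the chain of compound 2.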